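The source may hold more compounds than are shown below. What is called first, only, known or untested is meant among the compounds shown, and "the series" means these compounds.

The series is built on a shared core carrying two propargyloxy-substituted phenyl groups, and the compounds are compared in an assay on BTI-TN-5B1-4 cells for inhibition of Amine oxidase [flavin-containing] A (Homo sapiens), read by fluorescence and Amplex Red, using microsomes, with a stated time of 30 min; on this read-out lower numbers stand for stronger inhibition and higher numbers for weaker inhibition. Compound 1 `C#CCOc1ccc(-c2cc(-c3ccc(OCC#C)cc3)nc(-c3ccccc3)n2)cc1` carries a phenyl group on the core and two para-substituted aryl groups; in this assay compound 1 gives 25600 nM. Compound 2 `C#CCOc1ccc(-c2cc(-c3ccc(OCC#C)c(OC)c3)nc(N)n2)cc1` replaces that phenyl with an amino group and adds a methoxy group on one aryl ring; in this assay compound 2 is reported as "not active" (no number reported). Compound 3 `C#CCOc1cccc(-c2cc(-c3cccc(OCC#C)c3)nc(-c3ccccc3)n2)c1` keeps the phenyl group of compound 1 but moves both propargyloxy groups to the meta position of their rings; in this assay compound 3 is likewise reported as "not active" (no number reported). Compound 3 therefore stands without a number of its own, and it shares this outcome with compound 2, so only compound 1 yields a concentration in the whole set.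

Compound 4 `C#CCOc1cccc(-c2cc(-c3cccc(OCC#C)c3)nc(N)n2)c1` is the step from compound 3 that follows here: amino in place of phenyl on an aromatic carbon. Going by the values given here, no measured pair shows this exchange on its own, and the one amino-bearing compound measured, compound 2, gives "not active" (no number reported). Weak inhibition is therefore expected, with a real chance that this assay again returns no number. Compound 4 is estimated at 60000 nM, within a range from 15000 nM to 250000 nM.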

Compound 4, half-maximal inhibitory concentration: "not active" (no number reported)
No number was reported for compound 4; there is nothing to compare the estimate with.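

Going by these compounds alone, compound 3 and compound 4 are both reported as "not active" with no number, so no step from phenyl to amino can be read between them. No measured evidence bears on this outcome. The compounds shown leave open how amino in place of phenyl would change inhibition in a compound that gives a number.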